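A Bromo Substituent Added to a Benzylamine Propanoic Acid

A few compounds are considered here, and "the series" means these few. Any claim that something is new, unique, unknown or untested is made for them only; others in the source may bear on it.

Measured compounds, with their largest response in a functional assay on 1321-N1 cells for agonist activity at Free fatty acid receptor 1 (Homo sapiens), read by calcium flux; on this read-out lower numbers stand for smaller maximal responses and higher numbers for larger maximal responses:
compound 1, `O=C(O)CCc1ccc(NCc2ccccc2)cc1`, gives 89%;
compound 2, `O=C(O)CCc1ccc(OCc2ccccc2)c(I)c1`, gives 81%;
compound 3, `O=C(O)CCc1ccc(OCc2ccc(Br)cc2)cc1`, gives 98%.

Compound 1 stands second highest of the three numbers. Its nearest neighbour is compound 2, whose value lies a little lower, and the furthest is compound 3, whose value lies a little higher; both gaps fall within the usual scatter of this kind of measurement, so the three compounds cannot be told apart on these numbers.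

Compound 4, `O=C(O)CCc1ccc(NCc2cccc(Br)c2)cc1`, differs from compound 1 in one place: bromo in place of hydrogen on an aromatic carbon. The new bromo sits on an aromatic carbon of a six-membered aromatic ring of carbon only, meta to a large group.

Going by the values given here, no measured pair that differs in a single place is available here, so the effect of this change has to be guessed. The three measured values all lie close together, and none of them shows a large shift; the step in this assay is therefore expected to be small, likely no larger than the scatter, with no clear direction. The expected step of a number 3 percentage points higher from compound 1 to compound 4 (within the scatter) reflects this. Compound 4 is estimated to give 92%, with a range from 78% to 105%.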

Compound 4, largest response reached (reported as efficacy), in percent of the reference or control that the assay uses: 110%
Estimate against measurement, compound 4: 18 percentage points below; the whole stated range lies below it.
By their numbers in this assay, from the lowest: compounds 2, 1 and 3 (each within the scatter of the next, the first and the last beyond it); then compound 4.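

In this assay, bromo in place of hydrogen on an aromatic carbon, meta to a large group, gives a step of a number 21 percentage points higher from compound 1 to compound 4 (beyond the scatter). This is the first change in a single place among these compounds, and it shows that this position is not indifferent: one added heavy atom is enough to shift the maximal response by more than the usual scatter. No measurement here says why the response rises with this change.

From the compounds shown here alone, it remains open whether the gain belongs to bromo itself or would also appear with chloro, methyl or methoxy on the same carbon. Going by these compounds, it is also open whether bromo on another carbon of this ring would give a similar step, and whether the step would hold on a different core.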